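This account rests on a few compounds, and the source may have more. Where it says the series, first, only, none or still open, it means among the compounds named here.

Measured so far:
compound 1 `Cc1cc(-c2ccccc2)n(/C(N)=N/S(=O)(=O)c2cc(C)c(Cl)cc2SCc2cccc3ccccc23)n1` — in an ADME assay on HaCaT cells (Homo sapiens) for cytotoxicity, read by MTT assay, with a stated time of 72 h (on this read-out higher numbers stand for weaker inhibition and lower numbers for stronger inhibition), compound 1 gives 12000 nM
compound 2 `Cc1cc(S(=O)(=O)/N=C(\N)n2nccc2-c2ccccc2)c(SCc2ccccc2)cc1Cl` — compound 2 gives 18000 nM
compound 3 `Cc1cc(S(=O)(=O)/N=C(\N)n2nccc2-c2ccccc2)c(SCc2cccc3ccccc23)cc1Cl` — compound 3 gives 11000 nM

Compound 1 stands second highest of the three numbers, all three lying within the scatter of one another: a 1.1-fold lower number from compound 1 to compound 3 (0.04 log units; within the scatter) is within the scatter, and the gap to compound 2 is of the same order.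

Compound 4 `Cc1cc(-c2ccccc2)n(/C(N)=N/S(=O)(=O)c2cc(C)c(Cl)cc2SCc2ccc(Cl)cc2)n1` differs from compound 1 by 4-chlorophenyl in place of naphthalen-1-yl on a saturated chain carbon bound to a sulfur. Among the measured compounds shown here, the only measured step at this place is a 1.6-fold lower number from compound 2 to compound 3 (0.21 log units; within the scatter), within the scatter; the present change runs the other way, with a chlorine on the entering ring, so a step in this assay beyond the scatter is not expected. Compound 4 is expected at 15000 nM (range 7000 nM to 32000 nM), an estimated step of a 1.3-fold higher number from compound 1 to compound 4 (0.10 log units; within the scatter).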

Compound 4, half-maximal inhibitory concentration: 11000 nM
Compound 4: middle estimate off by 1.4-fold (0.13 log units), on the high side; the range from low to high includes it.
By their numbers in this assay, from the lowest: compounds 3, 4, 1 and 2 (each within the scatter of the next).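

At the saturated chain carbon bound to a sulfur, this assay shows a 1.1-fold lower number from compound 1 to compound 4 (0.04 log units; within the scatter) when 4-chlorophenyl takes the place of naphthalen-1-yl. On the core of compound 1, then, an exchange that drops one aromatic ring and brings in a chlorine stays within the scatter, as the step on the other core did. No measurement here accounts for this result. From the compounds shown here alone, whether an amine or a carboxylic acid in place of the 4-chlorophenyl, or a longer chain on the sulfur, would give a step beyond the scatter remains open.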